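A few compounds are considered here, and "the series" means these few. Any claim that something is new, unique, unknown or untested is made for them only; others in the source may bear on it.

Compound 1 `Nc1nn(C(=O)Nc2ccc(Cc3ccccc3)cc2)c2ccccc12` is one of two ureas built on the shared core. Going by the values given here, in a functional assay on NCI-H23 cells (Homo sapiens) for inhibition, read by sulforhodamine B assay, with a stated time of 48 h (a higher number here means a weaker inhibitor of growth, a lower number a stronger inhibitor of growth), compound 1 gives 16800 nM, the only number among the two values shown. Compound 2 `COc1ccc(NC(=O)Nc2n[nH]c3ccccc23)cc1` gives only a limit of the assay, > 100000 nM. Among the compounds with values here, this places compound 1 at the one measured value, with one companion at a limit (the limit of > 100000 nM in this assay, at which 1 of the 2 values shown sits). Compound 3 `CCCCOc1ccc(NC(=O)n2nc(N)c3ccccc32)cc1` differs from compound 1 by butoxy in place of benzyl on an aromatic carbon. With no measured step of this kind shown, a loss somewhat beyond the scatter is expected, a 1.8-fold higher number from compound 1 to compound 3 (0.25 log units; within the scatter), and compound 3 is estimated at 30000 nM, within 8000 nM to 100000 nM.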

Compound 3, concentration for 50% growth inhibition: 19400 nM
Compound 3: the middle estimate sits 1.5-fold (0.19 log units) above what was measured; low and high end bracket the measured number.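

In this assay, butoxy in place of benzyl on an aromatic carbon, para to a large group, gives a 1.2-fold higher number from compound 1 to compound 3 (0.06 log units; within the scatter) and so no change beyond the scatter. At this position, then, a group with no ring and a group holding a six-membered aromatic ring of carbon only read alike in this one pair. Nothing measured here gives a reason for this. Going by these compounds, whether an amine, a carboxylic acid or a longer chain at the same place would read alike remains open.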